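The source may report more compounds than this note shows. Statements on the series, on what has been measured and on what is new or still open speak of the compounds shown alone.

Compound 1, `CCC/N=C1\S/C(=C\c2ccc(O)c(Cl)c2)C(=O)N1C1CC1`: 79000 nM
Compound 2, `CCC/N=C1\S/C(=C\c2ccc(O)c(Br)c2)C(=O)N1c1ccccc1C`: 79000 nM
Compound 3, `CCC/N=C1\S/C(=C\c2ccc(O)c(Cl)c2)C(=O)N1c1ccccc1OC`: 79000 nM

In a physicochemical assay for solubility, measured as kinetic solubility (on this read-out higher numbers stand for higher solubility and lower numbers for lower solubility), compound 2 stands level with compounds 1 and 3 at the digits shown; the nearest is compound 1, with no change within the scatter, and the furthest is compound 3, again with no change within the scatter. Compound 4, `CCC/N=C1\S/C(=C\c2ccc(O)c(C#N)c2)C(=O)N1c1ccccc1C`, has not yet been measured in this assay. It differs from compound 2 by cyano in place of bromo on an aromatic carbon. Among the measured compounds shown here, the only step measured so far, no change at the digits printed from compound 1 to compound 3 (within the scatter), concerns a different place, the amide-type nitrogen in the ring, and was flat. For the measured compounds named here, no measured step alters the group on the aromatic carbon that sits ortho to the hydroxy group; compounds 1 and 2 differ there, and compound 1 gives 79000 nM while compound 2 gives 79000 nM, so the two values show no separation. On this footing the step of no change at the digits printed from compound 2 to compound 4 (within the scatter) is expected to be none beyond the scatter. The estimate for compound 4 in this assay is 79000 nM, with a range from 40000 nM to 160000 nM.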

Compound 4, solubility: 220000 nM
The estimate for compound 4 lay 2.8-fold (0.44 log units) below the measured number; the whole stated range lies below it.
By their numbers in this assay, from the lowest: compounds 1, 2 and 3 (each within the scatter of the next); then compound 4.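

In this assay, the place ortho to a hydroxy group proves able to move the number on its own: cyano in place of bromo gives a 2.8-fold higher number from compound 2 to compound 4 (0.44 log units; beyond the scatter), with the rest of the structure unchanged. The only other step between compounds differing in one place, no change at the digits printed from compound 1 to compound 3 (within the scatter), concerned the amide-type nitrogen in the ring, so this is the only step shown that lies beyond the scatter and the only one that reads this position by itself. The exchange replaces one heavy atom with two and adds one hydrogen-bond acceptor, but nothing available explains why the number changes with it.

This single exchange leaves open whether the step is particular to cyano or would also appear with another group at this place, such as fluoro, a primary amide or a carboxylic acid. It also leaves open whether cyano in place of bromo would give a step of similar size with a different group on the amide-type nitrogen, such as the cyclopropyl of compound 1 or the 2-methoxyphenyl of compound 3.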